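Amide aryl change on compound 1

The source may report more compounds than this note shows. Statements on the series, on what has been measured and on what is new or still open speak of the compounds shown alone.

- compound 1 `O=C(CN1CCN(c2nnc(Cc3ccncc3)c3ccccc23)CC1)Nc1ccc(Br)cc1` gives 19 nM
- compound 2 `O=C(CN1CCN(c2nnc(Cc3ccccc3)c3ccccc23)CC1)Nc1ccc(F)c(C(F)(F)F)c1` gives 760 nM
- compound 3 `Cc1ccccc1NC(=O)CN1CCN(c2nnc(Cc3ccccc3)c3ccccc23)CC1` gives 17300 nM

Compound 1 holds the lowest of these three numbers in a functional assay on MDA-MB-231 cells (Homo sapiens) for cytotoxicity, read by MTT assay, with a stated time of 72 h (on this read-out higher numbers stand for weaker inhibition and lower numbers for stronger inhibition), with both gaps to the other compounds beyond the scatter. Compound 4 `Cc1ccc(F)cc1NC(=O)CN1CCN(c2nnc(Cc3ccncc3)c3ccccc23)CC1` has 5-fluoro-2-methylphenyl in place of 4-bromophenyl on an amide-type nitrogen.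

For the measured compounds named here, only one measured step bears on this change. It is a 23-fold higher number from compound 2 to compound 3 (1.36 log units; beyond the scatter), a large step beyond the scatter, with 2-methylphenyl replacing 4-fluoro-3-(trifluoromethyl)phenyl on an amide-type nitrogen. The transfer is uncertain: the core of compound 2 and compound 3 is not that of compound 1, and the group leaving there is a different one. Going by the values given here, no measured pair isolates the fluoro group of compound 4, and none starts from 4-bromophenyl.

A sizeable rise in this assay is therefore expected, towards weaker inhibition. The expected step is an 18-fold higher number from compound 1 to compound 4 (1.27 log units; beyond the scatter), of similar order to the measured one. For compound 4 the estimated value is 350 nM, with an expected range from 60 nM to 2500 nM.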

Compound 4, half-maximal inhibitory concentration: 6.4 nM
Estimate against measurement, compound 4: 55-fold (1.74 log units) above; measured number below the stated range.
By their numbers in this assay, from the lowest: compound 4; then compound 1; then compound 2; then compound 3.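

In this assay the change on the amide-type nitrogen runs towards stronger inhibition, with a 3.0-fold lower number from compound 1 to compound 4 (0.47 log units; beyond the scatter) as the step, so 4-bromophenyl does not mark the best result at this place on the core of compound 1. A methyl-bearing aryl group is thus compatible with a low number on this core, which a 23-fold higher number from compound 2 to compound 3 (1.36 log units; beyond the scatter) did not suggest, although that step has a different core and a different leaving group. Nothing measured here explains the lower number.

The compounds shown do not separate the fluoro group from the methyl group of 5-fluoro-2-methylphenyl on this core. Also open, from the compounds shown here alone, is how an amine or a carboxylic acid on the aryl ring would read in this assay on the core of compound 1.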